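Sulfonyl aryl series: 4-methoxyphenyl to 4-fluorophenyl

The source may report more compounds than this note shows. Statements on the series, on what has been measured and on what is new or still open speak of the compounds shown alone.

In an ADME assay on HEK-293T cells (Homo sapiens) for inhibition, read by CCK-8 assay, with a stated time of 48 h, tested at 20 uM (a higher number here means more inhibition of growth at the concentration tested, a lower number less inhibition of growth), compound 3 `COc1ccc(S(=O)(=O)Oc2ccccc2/C=C(\C#N)C(=O)Nc2nnc(Cc3ccc(Cl)cc3)s2)cc1` gives 26%. Compound 2 `Cc1ccc(S(=O)(=O)Oc2ccccc2/C=C(\C#N)C(=O)Nc2nnc(Cc3ccc(Cl)cc3)s2)cc1` gives 20%, within the scatter of compound 3. Compound 1 `COc1ccc(Cc2nnc(NC(=O)/C(C#N)=C/c3ccccc3OS(=O)(=O)c3ccc(F)cc3)s2)cc1` gives 6%, lower than compound 3 and beyond the scatter. Compound 4 `N#C/C(=C\c1ccccc1OS(=O)(=O)c1ccc(F)cc1)C(=O)Nc1nnc(Cc2ccc(Cl)cc2)s1` follows from compound 3 by one change: fluoro in place of methoxy on an aromatic carbon. This is fluoro in place of methoxy, para to a large group. For the measured compounds named here, the only measured step at this place, a number 6 percentage points higher from compound 2 to compound 3 (within the scatter), stays within the scatter, so no step beyond the scatter is expected in this assay. Compound 1 also carries the 4-fluorophenyl group but differs elsewhere, so the expectation leans slightly downward. The expected change is a number 5 percentage points lower from compound 3 to compound 4 (within the scatter). For compound 4 the estimate is 21%, with an expected range of 8% to 36%.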

Compound 4, percent growth inhibition at one concentration: 14%
For compound 4 the middle estimate is 7 percentage points above the measured one; low and high end bracket the measured number.
By their numbers in this assay, from the lowest: compounds 1, 4, 2 and 3 (each within the scatter of the next, the first and the last beyond it).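

In this assay, for the compounds shown here, 4-fluorophenyl in place of 4-methoxyphenyl gives the first step beyond the scatter at this position, a number 12 percentage points lower from compound 3 to compound 4 (beyond the scatter), while a number 6 percentage points lower from compound 2 to compound 4 (within the scatter) leaves compound 2 within the scatter of both compound 3 and compound 4. With the 4-fluorophenyl group held, chloro in place of methoxy at the other place gives a number 8 percentage points higher from compound 1 to compound 4 (within the scatter) and so adds no step beyond the scatter there.

Going by these compounds, an amine or a carboxylic acid on this aromatic carbon remains open. No measurement at hand gives a reason for these steps.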